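The source may report more compounds than this note shows. Statements on the series, on what has been measured and on what is new or still open speak of the compounds shown alone.

Working notes on the series. The shared core runs through compound 1 `Cn1c(=O)[nH]c2ccc(OCc3cccc(F)c3)cc21`, compound 2 `Cn1c(=O)[nH]c2ccc(OCc3ccccc3)cc21` and compound 3 `Cn1c(=O)[nH]c2ccc(OCc3cccc(Cl)c3)cc21`. In an assay on cells for inhibition of Amine oxidase [flavin-containing] B (Homo sapiens), read by fluorescence, with stated times of 30 min and 15 min, tested at 1 uM (on this read-out lower numbers stand for less inhibition and higher numbers for more inhibition at the one concentration tested (going by the name of the read-out)), compound 1 gives 5.36%, compound 2 gives "not active" (no number reported) with no number reported, and compound 3 gives 8.89%. Among the compounds with values here, compound 3 thus stands highest of the two numbers, yet the single step on record, a number 3.5 percentage points higher from compound 1 to compound 3 (within the scatter), lies within the scatter, so no order among the three is secured. Compound 4 `Cn1c(=O)[nH]c2ccc(OCc3ccc(Cl)c(Cl)c3)cc21` is next; its change from compound 3: chloro in place of hydrogen on an aromatic carbon. Within the data shown here, no measured step covers this particular change, and the one step available, chloro in place of fluoro, was small. Compound 4 is therefore expected to show a step of a number 3.1 percentage points higher from compound 3 to compound 4 (within the scatter) that stays within the scatter. The estimate for compound 4 in this assay is 12%, with a range from 0% to 30%.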

Compound 4, a percentage reported as inhibition, at one concentration (the size of the read-out at that concentration, not a potency): 32.4%
Beside the measured number, compound 4's estimate is 20.4 percentage points below it; the measured number lies above the stated range.
By their numbers in this assay, from the lowest: compounds 1 and 3 (each within the scatter of the next); then compound 4.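

Chloro in place of hydrogen on an aromatic carbon, ortho to a chloro group and para to a large group, gives a number 23.5 percentage points higher from compound 3 to compound 4 (beyond the scatter) in this assay. Within the data shown here, this is the first step to clear the scatter, whereas the swap of chloro for fluoro gave only a number 3.5 percentage points higher from compound 1 to compound 3 (within the scatter). Nothing at hand accounts for this step.

On these data alone, whether this position alone carries the gain, or the two chloro groups are needed together, remains open. Also open, as far as these compounds go, is how an amine, a methoxy group or a carboxylic acid would fare at this position.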